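Vinyl in Place of Ethyl on a Shared Core

This account rests on a few compounds, and the source may have more. Where it says the series, first, only, none or still open, it means among the compounds named here.

Compound 1 `CCN(C(=O)C1CCN(S(=O)(=O)c2ccc3cn[nH]c3c2)CC1)[C@H](C)c1ccccc1`: 87%
Compound 2 `CCN(Cc1ccccc1C(F)(F)F)C(=O)C1CCN(S(=O)(=O)c2ccc3[nH]ncc3c2)CC1`: 96%
Compound 3 `CCCN(Cc1ccccc1C(F)(F)F)C(=O)C1CCN(S(=O)(=O)c2ccc3[nH]ncc3c2)CC1`: 94%

All three compounds were tested in a functional assay on CHO cells for positive allosteric modulation of muscarinic acetylcholine receptor M5 (Homo sapiens), read by calcium flux (on this read-out lower numbers stand for smaller maximal responses and higher numbers for larger maximal responses), and their numbers lie close together. Compound 3 is the one compared here: compound 2 lies nearest to it and compound 1 furthest, yet both gaps are within the usual scatter, so the three numbers cannot be told apart. For the measured compounds named here, the one single-point step among the measured compounds, a number 2 percentage points lower from compound 2 to compound 3 (within the scatter), puts a methyl in place of a hydrogen on a saturated chain carbon two bonds along the chain from an amide-type nitrogen and changed nothing beyond the scatter.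

Compound 4 `C=CCN(Cc1ccccc1C(F)(F)F)C(=O)C1CCN(S(=O)(=O)c2ccc3[nH]ncc3c2)CC1` has not been measured. It differs from compound 3 by vinyl in place of ethyl on a saturated chain carbon bound to an amide-type nitrogen. This is again a small change on the same chain, one bond closer to the amide-type nitrogen than the step from compound 2 to compound 3, which itself stayed within the scatter. Going by the values given here, no measured step introduces a double bond, so nothing shows how one would act; the nearest guide is that chain edits here have left the maximal response unchanged.

The step from compound 3 to compound 4 is therefore expected to be a number 1 percentage points lower from compound 3 to compound 4 (within the scatter), within the scatter. Compound 4 is estimated at 93%, in a range from 82% to 102%.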

Compound 4, largest response reached (reported as percent of maximum), in percent of the reference or control that the assay uses: 79%
For compound 4 the middle estimate is 14 percentage points above the measured one; the measured number lies below the stated range.
By their numbers in this assay, from the lowest: compounds 4, 1, 3 and 2 (each within the scatter of the next, the first and the last beyond it).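

In this assay, for the compounds shown here, this chain position proves sensitive to the kind of group it carries, not only to its size: vinyl in place of ethyl on a saturated chain carbon bound to an amide-type nitrogen, a swap that leaves the count of heavy atoms unchanged, gives the first change here that clears the scatter (a number 15 percentage points lower from compound 3 to compound 4 (beyond the scatter)). Measured against the shorter chain, vinyl in place of methyl gives a step of similar size (a number 17 percentage points lower from compound 2 to compound 4 (beyond the scatter)), while lengthening the saturated chain alone stayed within the scatter (a number 2 percentage points lower from compound 2 to compound 3 (within the scatter)), so among these compounds the lower maximal response goes with the double bond and not with chain length. Nothing in the data available here explains how the double bond lowers the response.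

Still open, from the compounds shown here alone, is whether a propargyl group, with its triple bond, or a cyclopropylmethyl group in the same place would behave like the allyl chain of compound 4 or like the propyl chain of compound 3. A longer saturated chain such as butyl would also show how far the tolerance for saturated chains at this position extends.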